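Ethyl to Difluoromethoxy: A Step Without a Close Precedent

The compounds below may be only part of what the source reports. "The series", "measured", "known", "first", "only" and "open" are said of these compounds alone.

Compound 1, `CCCCCc1ccc(NS(=O)(=O)c2ccc(N3CCNC3=O)cc2)cc1`: 870 nM
Compound 2, `CCc1ccc(NS(=O)(=O)c2ccc(N3CCNC3=O)cc2)cc1`: 480 nM

Both compounds were tested in a functional assay on M21 cells (Homo sapiens) for antiproliferative activity, read by sulforhodamine B assay, with a stated time of 48 h; a higher number here means a weaker inhibitor, a lower number a stronger inhibitor. Among the compounds with values here, compound 2 has the lowest of the two numbers, but its only neighbour is compound 1, and the step of a 1.8-fold lower number from compound 1 to compound 2 (0.26 log units; within the scatter) does not separate them: the two values sit within the usual scatter of each other.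

Compound 3, `O=C1NCCN1c1ccc(S(=O)(=O)Nc2ccc(OC(F)F)cc2)cc1`, differs from compound 2 by difluoromethoxy in place of ethyl on an aromatic carbon. Within the data shown here, the one measured step, from compound 1 to compound 2, also alters the group on that aromatic carbon, and it stayed within the scatter. Among the measured compounds shown here, no measured step exchanges an alkyl group for an oxygen-linked, fluorinated group, so there is no direct guide to this change. The step of a 1.0-fold higher number from compound 2 to compound 3 (0.02 log units; within the scatter) is therefore expected to be small, with no clear direction beyond the scatter. For compound 3 the expected value is 500 nM, with a range from 150 nM to 1700 nM.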

Compound 3, half-maximal inhibitory concentration: 410 nM
The estimate for compound 3 lay 1.2-fold (0.09 log units) above the measured number; the range from low to high includes it.
By their numbers in this assay, from the lowest: compounds 3, 2 and 1 (each within the scatter of the next, the first and the last beyond it).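

Within the data shown here, on this aromatic carbon, difluoromethoxy brings in oxygen and fluorine where the earlier compounds carry only alkyl chains, yet in this assay the change from ethyl gives a 1.2-fold lower number from compound 2 to compound 3 (0.07 log units; within the scatter) and does not separate the two groups. Against the longer chain, the same group gives a 2.1-fold lower number from compound 1 to compound 3 (0.33 log units; beyond the scatter), a modest step and the only one so far to pass the scatter, while compound 2 stays within the scatter of both other compounds. Nothing measured here indicates what lies behind these numbers.

Open, on these data alone, is whether the oxygen or the fluorine atoms of difluoromethoxy count for anything at this place, a question that a plain methoxy group or a trifluoromethyl group could address. Also open, as far as these compounds go, is how this place would respond to an amine or a carboxylic acid.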